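Hydroxymethyl for methylsulfonyl: cytotoxicity across two cores

This account rests on a few compounds, and the source may have more. Where it says the series, first, only, none or still open, it means among the compounds named here.

Compound 1 `CS(=O)(=O)CCCn1c(Cn2c(=O)n(C3CC3)c3ccncc32)nc2nc(Cl)ccc21` was run in an ADME assay on HeLa cells (Homo sapiens) for cytotoxicity, read by ATP content, with a stated time of 3 days; a higher number here means that more compound is tolerated, a lower number that less compound is tolerated. In this assay compound 1 gives > 50000 nM, which is a limit of the assay and not a number. Compound 2 `O=c1n(Cc2nc3nc(Cl)ccc3n2CCCCO)c2cnccc2n1C1CC1` differs from compound 1 by hydroxymethyl in place of methylsulfonyl on a saturated chain carbon, three bonds along the chain from an aromatic nitrogen. In this assay compound 2 gives > 50000 nM, again a limit of the assay. The step that the two limits leave unreadable from compound 1 to compound 2 is therefore not readable. Compound 3 `CS(=O)(=O)CCCn1c(Cn2c(=O)n(C3CC3)c3ccncc32)cc2cc(F)ccc21` carries a different core; the difference between the two cores is not broken down here. In this assay compound 3 gives > 50000 nM, a limit of the assay. Within the data shown here, compound 4 `O=c1n(Cc2cc3cc(F)ccc3n2CCCCO)c2cnccc2n1C1CC1` differs from compound 3 by hydroxymethyl in place of methylsulfonyl on a saturated chain carbon, three bonds along the chain from an aromatic nitrogen, the same change as the one from compound 1 to compound 2. For compound 4 the expected step is a step that the limit leaves unreadable from compound 3 to compound 4, set beside the unreadable a step that the two limits leave unreadable from compound 1 to compound 2, and the expectation rests on (the limit of > 50000 nM in this assay, at which 3 of the 3 values shown sit). Compound 4 is accordingly expected to give 80000 nM, most probably reported as a limit once more, with the expected range running from 30000 nM to 300000 nM.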

Compound 4, half-maximal cytotoxic concentration: > 50000 nM
Compound 4: no number, only a limit; the forecaster's own chance of this, stated with the estimate: 85%; the middle value lies beyond the limit too.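

In this assay compound 4 gives > 50000 nM, a limit of the assay and not a number. Among these compounds, compound 3 gives > 50000 nM, also a limit, so no step from compound 3 to compound 4 can be read. The compounds shown leave open at what concentration compound 1, compound 2, compound 3 or compound 4 becomes cytotoxic, and whether hydroxymethyl in place of methylsulfonyl shifts that concentration on either core.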